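The compounds below may be only part of what the source reports. "The series", "measured", "known", "first", "only" and "open" are said of these compounds alone.

Measured in a physicochemical assay for lipophilicity, at pH 7.4; on this read-out higher numbers stand for higher lipophilicity and lower numbers for lower lipophilicity:
- Compound 1 `Cc1cc(C(=O)Nc2ccccn2)nn1Cc1cc(Cl)ccc1OCc1ccccc1`: > 3.7, a limit
- Compound 2 `Cc1cc(C(=O)NCc2ccccc2)nn1Cc1cc(Cl)ccc1OCc1ccccc1`: > 3.7, a limit
- Compound 3 `Cc1cc(NC(=O)C(C)C)nn1Cc1cc(Cl)ccc1OCc1ccccc1`: > 3.7, a limit

Compound 3 has no number in this assay, only the limit > 3.7. The series as a whole stands at the limit of > 3.7 in this assay, at which 3 of the 3 values shown sit.

Compound 4 `Cc1cc(NC(=O)CC(C)(C)C)nn1Cc1cc(Cl)ccc1OCc1ccccc1` carries neopentyl in place of isopropyl on a carbonyl carbon.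

Two measured steps reach compound 3: a step that the two limits leave unreadable from compound 1 to compound 3 and a step that the two limits leave unreadable from compound 2 to compound 3. Neither gives a size, and neither changes the group on the carbonyl carbon, so the expectation rests on the structural change and on the limit of compound 3 alone. Among the measured compounds shown here, the expected step is a step that the limit leaves unreadable from compound 3 to compound 4, taken as modest and upward, with no measured step to confirm its size. A further report as a limit is the likeliest outcome in this assay. For compound 4 the estimate is 4.2, with an expected range of 3.8 to 4.8.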

Compound 4, distribution coefficient: > 3.7
Compound 4: only a limit was reported; the forecaster's own chance of this, stated with the estimate: 85%; the middle value does not contradict the limit.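

No step can be read from compound 4 to compound 1, compound 2 or compound 3 in this assay, because all four compounds are reported only as the same limit: the limit of > 3.7 in this assay, at which 4 of the 4 values shown sit.

The compounds shown leave open the size of any difference among them in this assay, including that of neopentyl in place of isopropyl on a carbonyl carbon.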